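A few compounds are considered here, and "the series" means these few. Any claim that something is new, unique, unknown or untested is made for them only; others in the source may bear on it.

Measured compounds in a functional assay on MCF7 cells (Homo sapiens) for cytotoxicity, read by MTT assay, with a stated time of 72 h; on this read-out higher numbers stand for weaker inhibition and lower numbers for stronger inhibition:

- Compound 1 `CNC(=O)c1cc(Oc2ccc(NC(=O)c3cc(-c4ccc(Br)cc4)ncn3)cc2)ccn1` gives > 100000 nM in this assay; this value is a limit of the assay, not a number.
- Compound 2 `CNC(=O)c1cc(Oc2ccc(NC(=O)c3cc(-c4ccc(Br)cc4)ncn3)cc2F)ccn1` gives > 100000 nM in this assay; this value too is a limit of the assay, not a number.
- Compound 3 `CNC(=O)c1cc(Oc2ccc(NC(=O)c3nccc(-c4ccc(C)cc4)n3)cc2)ccn1` gives 44300 nM in this assay, the only number among the three.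

The change from compound 1 to compound 2 is fluoro in place of hydrogen on an aromatic carbon. The step it made in this assay is a step that the two limits leave unreadable from compound 1 to compound 2, which follows because both values sit at the limit of > 100000 nM in this assay, at which 2 of the 3 values shown sit. Nothing about the effect of this change can therefore be read from that pair.

Compound 3 carries a different core from compound 1; the difference between the two cores is not broken down here. Compound 4 `CNC(=O)c1cc(Oc2ccc(NC(=O)c3nccc(-c4ccc(C)cc4)n3)cc2F)ccn1` is not yet measured in this assay. It differs from compound 3 by fluoro in place of hydrogen on an aromatic carbon, the same change as from compound 1 to compound 2, made at the same place around it.

Among the compounds with values here, with the only measured instance of this change unreadable, the expectation for compound 4 rests on compound 3 alone, whose value in this assay is 44300 nM. The step from compound 3 to compound 4 in this assay is expected to be a 1.1-fold higher number from compound 3 to compound 4 (0.05 log units; within the scatter), that is, close to no change, with wide uncertainty in either direction. Compound 4 is thus estimated at 50000 nM in this assay, expected to fall between 15000 nM and 150000 nM, with a real chance that only a limit is reported.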

Compound 4, half-maximal inhibitory concentration: 69200 nM
Beside the measured number, compound 4's estimate is 1.4-fold (0.14 log units) below it; measured number inside the range.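

In this assay, fluoro in place of hydrogen on an aromatic carbon of the core of compound 3 makes a 1.6-fold higher number from compound 3 to compound 4 (0.19 log units; within the scatter), so this is one readable instance of the change, and on this core its size cannot be told apart from repeat-measurement noise. The matching pair on the core of compound 1 cannot be read, because compound 1 and compound 2 each give a limit of the assay and not a number: the limit of > 100000 nM in this assay, at which 2 of the 4 values shown sit. Within the data shown here, the series therefore offers no second step to set against the first, so it shows neither that the change carries from one core to the other nor that it fails to, and the step on the core of compound 3 cannot be assumed for any other core.

The compounds shown leave open whether a group other than fluoro, such as chloro, methoxy or an amine, ortho to a (2-(methylcarbamoyl)pyridin-4-yl)oxy group would give a step beyond the scatter in this assay. They also leave open what a carboxylic acid or a longer chain in place of the methyl of compound 3 would do on this core.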